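Urea-linked pyrazole series: cytotoxicity on lung carcinoma cells

The source may hold more compounds than are shown below. What is called first, only, known or untested is meant among the compounds shown, and "the series" means these compounds.

Measured so far:
- compound 1 `COc1cc(-c2nn(-c3cccc(NC(=O)Nc4cc(C(F)(F)F)cc(C(F)(F)F)c4)c3)cc2-c2ccncc2)ccc1Cl`: 18000 nM
- compound 2 `O=C(Nc1cccc(-n2cc(-c3ccncc3)c(-c3ccc(Cl)c(O)c3)n2)c1)Nc1ccc(Cl)c(Cl)c1`: > 32500 nM

Of the compounds shown here, two of the shared core have been read in a functional assay on A549 cells (Homo sapiens) for inhibition, read by sulforhodamine B assay, with a stated time of 48 h; on this read-out higher numbers stand for lower toxicity in this test and lower numbers for higher toxicity in this test. Within the data shown here, compound 1 gives 18000 nM and is the only compound with a number in this assay. Compound 2 reports a limit, > 32500 nM, not a number; the evidence on this point is the limit of > 32500 nM in this assay, at which 1 of the 2 values shown sits. With one number and one limit, compound 1 cannot be ranked against compound 2 beyond noting that its value lies under the limit.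

Among the measured compounds shown here, compound 3 `COc1cc(-c2nn(-c3cccc(NC(=O)Nc4cccc(C(F)(F)F)c4)c3)cc2-c2ccncc2)ccc1Cl` has not yet been read in this assay. It differs from compound 1 as follows: hydrogen in place of trifluoromethyl on an aromatic carbon. For the measured compounds named here, no measured pair here isolates the loss of a trifluoromethyl group, so the step is estimated from compound 1 alone. Loss of one trifluoromethyl group is expected to move the value little, if at all, and the step from compound 1 to compound 3 is estimated at a 1.2-fold higher number from compound 1 to compound 3 (0.09 log units; within the scatter), within the scatter of repeats. Compound 3 is therefore expected at 22000 nM, with a range of 10000 nM to 45000 nM, and a fair chance that this assay reports only a limit.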

Compound 3, concentration lethal to 50% of the cells: > 50000 nM
Compound 3 ended at the assay's limit; the forecaster's own chance of this, stated with the estimate: 35%; middle value at least 2.2-fold (0.35 log units) away from the limit.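

In this assay, hydrogen in place of trifluoromethyl on an aromatic carbon of a six-membered aromatic ring of carbon only, meta to a trifluoromethyl group, gives an at least 2.7-fold higher number from compound 1 to compound 3 (0.44 log units; beyond the scatter). Among these compounds, this is the first change read at a single place, and on this read-out it runs towards lower toxicity in this test, so this position is not silent to the change. The value of compound 3 is a limit of the assay and not a number: the limit of > 50000 nM in this assay, at which 1 of the 3 values shown sits.

On these data alone, the true size of the step stays open, as does whether it belongs to trifluoromethyl itself or would follow from any other group at this position, such as a methyl or a nitrile on the core of compound 3. Also open, as far as these compounds go, is whether the same change would act alike with the other substituents of the shared core, since this single pair covers only one background.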